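The source may hold more compounds than are shown below. What is called first, only, known or untested is meant among the compounds shown, and "the series" means these compounds.

Working notes on the series. The shared core of the series is seen in compound 2 `CN1CC=C(c2cn(-c3ccc(F)cc3)c3ccccc23)CC1` and compound 3 `CN1CC=C(c2cn(-c3ccc(F)cc3)c3ccc(Cl)cc23)CC1`. In a functional assay on the whole organism for inhibition, with Rattus norvegicus as the target (on this read-out lower numbers stand for an effect already at smaller amounts and higher numbers for an effect only at larger amounts of compound), compound 2 gives 0.15 umol/kg. In this assay compound 3 gives 0.058 umol/kg. The step of a 2.6-fold lower number from compound 2 to compound 3 (0.41 log units; beyond the scatter) is the only one in this set that joins two measured numbers. Compound 1 `O=C1NCCN1CCCCN1CCC(c2cn(-c3ccc(F)cc3)c3ccc(Cl)cc23)CC1` carries a longer chain from the ring amine nitrogen out to a 2-oxoimidazolidin-1-yl group. For compound 1 this assay returns only a limit, > 2.2 umol/kg; that is a limit of the assay and not a number, as shown by the limit of > 2.2 umol/kg in this assay, at which 1 of the 3 values shown sits. Compound 4 `O=C1NCCN1CCCCCN1CCC(c2cn(-c3ccc(F)cc3)c3ccc(Cl)cc23)CC1` differs from compound 1 in one place: (2-oxoimidazolidin-1-yl)methyl in place of 2-oxoimidazolidin-1-yl on a saturated chain carbon, four bonds along the chain from an amine nitrogen in a ring. Within the data shown here, no measured step touches this kind of change; the step from compound 2 to compound 3 concerns chloro in place of hydrogen on an aromatic carbon and gives no guide to a chain extension. The starting point being a limit, no direction can be read for compound 4 from the numbers shown. Compound 4 is therefore expected to stay near the limit region, with an estimated value of 4 umol/kg within a range of 0.6 umol/kg to 25 umol/kg. The implied step that the limit leaves unreadable from compound 1 to compound 4 is an estimate only, and the measurement for compound 4 is awaited.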

Compound 4, dose for half-maximal effect: 1.5 umol/kg
The estimate for compound 4 lay 2.7-fold (0.43 log units) above the measured number, and the stated range covers the measured number.
By their numbers in this assay, from the lowest: compound 3; then compound 2; then compound 4. At a limit, above all of these: compound 1.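

Compound 1 carries only a limit of the assay and not a number: the limit of > 2.2 umol/kg in this assay, at which 1 of the 4 values shown sits. With (2-oxoimidazolidin-1-yl)methyl in place of 2-oxoimidazolidin-1-yl on a saturated chain carbon, four bonds along the chain from an amine nitrogen in a ring, this position now gives a readable number, as compound 4 gives 1.5 umol/kg in this assay. The change reads as an at least 1.4-fold lower number from compound 1 to compound 4 (0.16 log units; that floor lies within the scatter), so the two compounds show that the longer chain is compatible with a measurable effect in the whole animal, but they fix neither the size of the change nor, with that floor inside the scatter, a firm direction.

The true distance between the two chain lengths stays open as long as compound 1 is held at a limit, and no cause for the result can be read from these compounds. Also open, going by these compounds, are a still longer chain at this position and an amine or a carboxylic acid in place of the 2-oxoimidazolidin-1-yl group at the chain end.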